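A Trifluoromethyl for a Methyl on the Benzyl Group

This account rests on a few compounds, and the source may have more. Where it says the series, first, only, none or still open, it means among the compounds named here.

Compound 1 `Cc1cccc(CSc2cc(Cl)c(C)cc2S(=O)(=O)/N=C(\N)n2nccc2-c2ccccc2)c1` is the reference point of this set. In a functional assay on HeLa cells (Homo sapiens) for cytotoxicity, read by MTT assay, with a stated time of 72 h (on this read-out higher numbers stand for weaker inhibition and lower numbers for stronger inhibition), compound 1 gives 8000 nM, the lowest of the three numbers measured. Compound 2 `Cc1cccc(CSc2cc(Cl)c(C)cc2S(=O)(=O)/N=C(\N)n2nc(C)cc2-c2ccccc2)c1` gives 155000 nM in this assay, and compound 3 `Cc1cc(-c2ccccc2)n(/C(N)=N/S(=O)(=O)c2cc(C)c(Cl)cc2SCc2ccccc2C)n1` gives 160000 nM. The step of a 19-fold higher number from compound 1 to compound 2 (1.29 log units; beyond the scatter) is large and beyond the scatter, whereas the step of a 1.0-fold higher number from compound 2 to compound 3 (0.01 log units; within the scatter) lies within it.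

Compound 4 `Cc1cc(S(=O)(=O)/N=C(\N)n2nccc2-c2ccccc2)c(SCc2cccc(C(F)(F)F)c2)cc1Cl` has not yet been measured. It differs from compound 1 in one place: trifluoromethyl in place of methyl on an aromatic carbon. Among the measured compounds shown here, no measured step exchanges this group on the benzyl group in the same way. The nearest comparison is the relocation of the methyl within that same benzyl group, a 1.0-fold higher number from compound 2 to compound 3 (0.01 log units; within the scatter), which left the number within the scatter; that step, however, was taken on compounds 2 and 3, both far weaker than compound 1, so it does not transfer directly. The methyl introduced on the shared core in a 19-fold higher number from compound 1 to compound 2 (1.29 log units; beyond the scatter) sits elsewhere in the molecule and says nothing about the change in hand.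

Compound 4 is therefore expected to show no change at the digits printed from compound 1 to compound 4 (within the scatter), an estimated 8000 nM, from 2500 nM to 25000 nM.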

Compound 4, half-maximal inhibitory concentration: 19000 nM
Beside the measured number, compound 4's estimate is 2.4-fold (0.38 log units) below it, and the stated range covers the measured number.
By their numbers in this assay, from the lowest: compound 1; then compound 4; then compounds 2 and 3 (each within the scatter of the next).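

In this assay, among the compounds shown here, putting trifluoromethyl in place of methyl on the benzyl group gives a 2.4-fold higher number from compound 1 to compound 4 (0.38 log units; beyond the scatter) and is a modest step beyond the scatter, the first reading of any change at this aromatic carbon on the core of compound 1. The position therefore responds to this exchange of one heavy atom for four, yet compound 4 remains well short of the large step of a 19-fold higher number from compound 1 to compound 2 (1.29 log units; beyond the scatter) produced by the added methyl on the shared core, so this change to the benzyl group costs far less than that one. No measurement shown bears on what lies behind the step, which therefore stays unexplained.

With only methyl and trifluoromethyl shown at this carbon, two groups cannot define a trend, and how a methoxy group, an amine or a carboxylic acid there would read in this assay remains open. Also open, going by these compounds, is whether the exchange would give a step of similar size on the methyl-bearing core of compound 2, or with the group placed as in the 2-methylphenyl of compound 3.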